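Side-Chain Exchange on Two Cores of Thromboxane Receptor Antagonists

A few compounds are considered here, and "the series" means these few. Any claim that something is new, unique, unknown or untested is made for them only; others in the source may bear on it.

Three compounds have so far been measured in a functional assay on a cell-free system (plasma) for inhibition of thromboxane A2 receptor (Homo sapiens), read by turbidimetry; a higher number here means a weaker inhibitor, a lower number a stronger inhibitor:

Compound 1, `O=C(O)COCCCC[C@H]1[C@H](F)CC[C@@H]1NS(=O)(=O)c1ccc(F)cc1`, gives 1800 nM.
Compound 2, `O=C(O)COCCCCC1=CCC[C@@H]1CNS(=O)(=O)c1ccc(F)cc1`, gives 200 nM.
Compound 3, `O=C(O)CC/C=C\C[C@H]1[C@H](F)CC[C@@H]1NS(=O)(=O)c1ccc(F)cc1`, gives 750 nM.

Compound 2 stands at the lowest number of the three; compound 3 is nearest to it and compound 1 furthest, both gaps lying beyond the scatter. Compounds 1 and 3 share a core and differ in one place, namely (4-carboxybut-1-en-1-yl in place of 3-(carboxymethoxy)propyl on a saturated chain carbon bound to a saturated ring carbon). The step this change made is a 2.4-fold lower number from compound 1 to compound 3 (0.38 log units; beyond the scatter), a modest but real move toward a stronger inhibitor. Compounds 1 and 2 carry different cores; how these cores differ is not broken down here.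

Compound 4, `O=C(O)CC/C=C\CC1=CCC[C@@H]1CNS(=O)(=O)c1ccc(F)cc1`, has not been measured in this assay. It differs from compound 2 by 4-carboxybut-1-en-1-yl in place of 3-(carboxymethoxy)propyl on a saturated chain carbon bound to a double-bonded ring carbon. The place is not the same word for word as in the earlier pair: there the chain carbon is bound to a saturated ring carbon, here to a double-bonded ring carbon. It is therefore the same kind of change, not the same change. The step from compound 2 to compound 4 is expected to be a 2.1-fold lower number from compound 2 to compound 4 (0.32 log units; beyond the scatter); this expectation rests on the step of a 2.4-fold lower number from compound 1 to compound 3 (0.38 log units; beyond the scatter), with added width since the core of compound 2 has not been tested with this change. For compound 4 the estimated value in this assay is 95 nM, expected to fall between 35 nM and 300 nM.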

Compound 4, half-maximal inhibitory concentration: 600 nM
Beside the measured number, compound 4's estimate is 6.3-fold (0.80 log units) below it; the measured number lies above the stated range.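

In this assay, putting 4-carboxybut-1-en-1-yl in place of 3-(carboxymethoxy)propyl on a saturated chain carbon bound to a double-bonded ring carbon gave a 3.0-fold higher number from compound 2 to compound 4 (0.48 log units; beyond the scatter), a move toward a weaker inhibitor. Set beside the earlier step, the same kind of change did not carry over from one core to the other, and its direction reversed: the same change on two cores in this assay, a 2.4-fold lower number (0.38 log units; beyond the scatter) from compound 1 to compound 3 and a 3.0-fold higher number (0.48 log units; beyond the scatter) from compound 2 to compound 4, 7.2-fold (0.86 log units) apart, beyond the scatter of two such steps This shows that in these two pairs the outcome of the side-chain exchange depends on the core that carries it, so a step read on one core is a poor guide to the other; it does not show which difference between the cores lies behind the reversal, and two pairs set no rule for any further core.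

The compounds shown leave open how the two side chains would behave on a core with neither the ring fluorine nor the ring double bond, which would help separate these features of the two cores. They also leave open whether a fully saturated chain without the ether oxygen, or a tetrazole in place of the carboxylic acid, would follow the step seen on the core of compound 1 or the one seen on the core of compound 2.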